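The source may report more compounds than this note shows. Statements on the series, on what has been measured and on what is new or still open speak of the compounds shown alone.

Three dichloroacetanilides have been examined in a functional assay on A549 cells (Homo sapiens) for antiproliferative activity, read by MTT assay, with a stated time of 72 h; on this read-out higher numbers stand for weaker inhibition and lower numbers for stronger inhibition. Compound 1, `O=C(Nc1cccc(I)c1)C(Cl)Cl`, gives 4760 nM. Compound 2, `COc1cccc(NC(=O)C(Cl)Cl)c1`, gives 25800 nM in this assay. Compound 3, `O=C(Nc1ccc(I)cc1)C(Cl)Cl`, gives 12500 nM in this assay, the second highest of the three numbers, with compound 2 nearest and compound 1 furthest from it. Compound 1 and compound 3 are built from the same atoms joined differently; how the two cores differ is not broken down here.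

The change from compound 1 to compound 2 is methoxy in place of iodo on an aromatic carbon. In this assay it made a 5.4-fold higher number from compound 1 to compound 2 (0.73 log units; beyond the scatter).

Compound 4, `COc1ccc(NC(=O)C(Cl)Cl)cc1`, has not yet been measured. It differs from compound 3 by methoxy in place of iodo on an aromatic carbon. Within the data shown here, this is the same kind of change as the one from compound 1 to compound 2, but the places are not the same: in the measured pair the group sits meta to a group of 6 heavy atoms, whereas in compound 3 and compound 4 it sits para to a group of 6 heavy atoms. Since the two cores are arranged differently, the step cannot be assumed to be identical.

The step from compound 3 to compound 4 in this assay is expected to be a 4.4-fold higher number from compound 3 to compound 4 (0.64 log units; beyond the scatter), an expectation that rests on the measured 5.4-fold higher number from compound 1 to compound 2 (0.73 log units; beyond the scatter). Compound 4 is therefore expected to give about 55000 nM in this assay, with a likely range from 20000 nM to 150000 nM.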

Compound 4, half-maximal inhibitory concentration: 80900 nM
Beside the measured number, compound 4's estimate is 1.5-fold (0.17 log units) below it, and the stated range covers the measured number.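

In this assay, methoxy in place of iodo on an aromatic carbon gave a 6.5-fold higher number from compound 3 to compound 4 (0.81 log units; beyond the scatter), and set beside the earlier step, the change carried over from one core to the other without a difference that can be told apart: the same change on two cores in this assay, a 5.4-fold higher number (0.73 log units; beyond the scatter) from compound 1 to compound 2 and a 6.5-fold higher number (0.81 log units; beyond the scatter) from compound 3 to compound 4, 1.2-fold (0.08 log units) apart, within the scatter of two such steps. For these two cores, then, the way the substituent is arranged on the ring made no discernible difference to the size of the step, and the step measured on one core was a fair guide to the step on the other. Among these compounds, this rests on only two pairs and a single exchange of groups, however, so it does not show that the step would hold on further cores, and it does not explain why methoxy gives the higher numbers in both pairs.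

The compounds shown carry only iodo and methoxy on the aromatic ring, which leaves open whether a step of similar size would follow with other groups in that place, such as an amine, a carboxylic acid or a longer alkoxy chain. From the compounds shown here alone, it also stays open whether the two steps would agree as closely on cell lines other than this one.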